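This account rests on a few compounds, and the source may have more. Where it says the series, first, only, none or still open, it means among the compounds named here.

Measured so far in an assay on isolated protein for inhibition of long-chain fatty acid transport protein 1 (Homo sapiens); on this read-out higher numbers stand for weaker inhibition and lower numbers for stronger inhibition:
Compound 1, `CCn1nnc(-c2ccc(NC(=O)CSc3nnc(CNc4ccccc4)n3CC)cc2)n1`, gives > 1000 nM.
Compound 2, `CCn1c(CNc2ccccc2)nnc1SCc1nc2cc(Cl)ccc2o1`, gives > 1000 nM.

The value for compound 2 is a limit of the assay, not a number. The value for compound 1 is likewise only a limit. On what is shown, compound 2 therefore sits where every value sits so far, described by the limit of > 1000 nM in this assay, at which 2 of the 2 values shown sit; nothing places it above or below compound 1.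

Compound 3, `CCn1c(CNc2ccccc2)nnc1SCc1nc2cc(C)ccc2o1`, has not yet been tested. It differs from compound 2 by methyl in place of chloro on an aromatic carbon. Within the data shown here, no measured pair of compounds differs in just one place, so nothing shows how such a change moves the read-out. With compound 2 already at the limit, no step beyond the usual scatter is expected in this assay, in either direction. Compound 3 is therefore expected to give about 3000 nM, within 800 nM to 20000 nM, an expected step that the limit leaves unreadable from compound 2 to compound 3 that will most likely be reported again only as a limit.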

Compound 3, half-maximal inhibitory concentration: > 1000 nM
Compound 3: only a limit was reported; the forecaster's own chance of this, stated with the estimate: 85%; the middle value lies beyond the limit too.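

No step can be read from compound 2 to compound 3, because each value is only a limit of the assay, not a number: the limit of > 1000 nM in this assay, at which 3 of the 3 values shown sit. The compounds shown leave open how strongly any of them inhibits the protein, and whether methyl in place of chloro changes that at all.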